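This account rests on a few compounds, and the source may have more. Where it says the series, first, only, none or still open, it means among the compounds named here.

Measured compounds:
compound 1 `COc1cnc(-c2ccccn2)nc1NCc1ccccc1` 420 nM
compound 2 `COc1cnc(-c2ccccn2)nc1NCc1ccccc1F` 130 nM
compound 3 `COc1cnc(-c2ccccn2)nc1NCc1ccc(F)cc1F` 110 nM

These three share one core and differ only in the ring hanging from the chain attached to the core. In a functional assay on RAW264.7 cells (Mus musculus), with a stated time of 3 days (a lower number here means a stronger inhibitor, a higher number a weaker inhibitor), compound 3 gives the lowest of the three numbers, but its nearest neighbour, compound 2, sits within the scatter of it a 1.2-fold lower number from compound 2 to compound 3 (0.07 log units; within the scatter), so the two cannot be told apart; only compound 1 stands clearly apart a 3.8-fold lower number from compound 1 to compound 3 (0.58 log units; beyond the scatter).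

Compound 4 `COc1cnc(-c2ccccn2)nc1NCc1ccccc1Cl` has not been measured. Compared with compound 3 it differs as follows: 2-chlorophenyl in place of 2,4-difluorophenyl on a saturated chain carbon bound to a nitrogen on an aromatic ring.

Two measured steps speak to this. Putting fluoro in place of hydrogen on an aromatic carbon gave a 3.2-fold lower number from compound 1 to compound 2 (0.51 log units; beyond the scatter), while the second such change gave only a 1.2-fold lower number from compound 2 to compound 3 (0.07 log units; within the scatter). Compound 4 keeps a single halogen in the first of these positions, so its number is expected to sit close to that of compound 2 and of compound 3, with a 1.3-fold higher number from compound 3 to compound 4 (0.10 log units; within the scatter) as the likely step. Compound 4 is therefore estimated at 140 nM, within 60 nM to 320 nM.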

Compound 4, half-maximal inhibitory concentration: 520 nM
Estimate against measurement, compound 4: 3.7-fold (0.57 log units) below; measured number above the stated range.
By their numbers in this assay, from the lowest: compounds 3 and 2 (each within the scatter of the next); then compounds 1 and 4 (each within the scatter of the next).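

In this assay, the drop in the number that fluoro brought on this ring does not extend to every halogen: chloro in place of fluoro on an aromatic carbon gives a 4.0-fold higher number from compound 2 to compound 4 (0.60 log units; beyond the scatter) and 2-chlorophenyl in place of 2,4-difluorophenyl gives a 4.7-fold higher number from compound 3 to compound 4 (0.67 log units; beyond the scatter) on the same chain carbon. Chloro in place of hydrogen gives only a 1.2-fold higher number from compound 1 to compound 4 (0.09 log units; within the scatter) and so leaves compound 4 indistinguishable from compound 1, which means that which halogen is present matters here, not just whether one is present. Nothing available explains why chloro and fluoro differ in this way.

Going by these compounds, it remains open whether a methyl or a methoxy group in the place of this chloro would behave like fluoro or like chloro. A 2,4-dichlorophenyl group would show whether a second chloro changes the number at all.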